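The source may report more compounds than this note shows. Statements on the series, on what has been measured and on what is new or still open speak of the compounds shown alone.

Measured so far in a functional assay on Jurkat cells for inhibition of nuclear factor NF-kappa-B complex (Homo sapiens); on this read-out higher numbers stand for weaker inhibition and lower numbers for stronger inhibition:
- compound 1 `CCOC(=O)c1cnc(-c2cnc3ccccc3c2)nc1NN1C(=O)C=C(C)C1=O` gives 6000 nM
- compound 2 `CCOC(=O)c1cnc(-c2ccc(Cl)cc2)nc1NN1C(=O)C=C(C)C1=O` gives 300 nM

Compound 2 stands at the lowest of the two numbers; its nearest neighbour is compound 1, and the step of a 20-fold lower number from compound 1 to compound 2 (1.30 log units; beyond the scatter) carries the whole spread of the set so far. For the measured compounds named here, that step exchanges the aryl group on the shared core, quinolin-3-yl for 4-chlorophenyl, and it is the only measured step that bears on the next one.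

Compound 3 `CCOC(=O)c1cnc(-c2cccc(Br)c2)nc1NN1C(=O)C=C(C)C1=O` is the next member: 3-bromophenyl in place of 4-chlorophenyl on an aromatic carbon. Going by the values given here, no measured pair shows this exact change, so the expectation rests on compound 2 alone and on the fact that the one measured aryl exchange was large. For compound 3 in this assay a number above that of compound 2 is expected, a step of about a 2.0-fold higher number from compound 2 to compound 3 (0.30 log units; within the scatter), with wide uncertainty because the measured step of a 20-fold lower number from compound 1 to compound 2 (1.30 log units; beyond the scatter) shows that aryl changes here can move the read-out strongly. The estimate for compound 3 is 600 nM, expected between 150 nM and 3000 nM.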

Compound 3, half-maximal inhibitory concentration: 700 nM
The estimate for compound 3 lay 1.2-fold (0.07 log units) below the measured number, and the stated range covers the measured number.
By their numbers in this assay, from the lowest: compound 2; then compound 3; then compound 1.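

In this assay, a second halogen-bearing phenyl at the aromatic carbon between two ring nitrogen atoms keeps the number well under that of the quinolin-3-yl compound, with an 8.6-fold lower number from compound 1 to compound 3 (0.93 log units; beyond the scatter) as the step. Exchange between the two halogen-bearing phenyls moves the read-out much less, yet a 2.3-fold higher number from compound 2 to compound 3 (0.37 log units; beyond the scatter) still lies beyond the scatter, so 4-chlorophenyl and 3-bromophenyl are distinguishable here; this step changes both the halogen and its ring position, and it cannot assign the shift to either one. No measurement at hand gives a reason for either step.

Still open, going by these compounds, is how 3-chlorophenyl or 4-bromophenyl would read, as either group would separate halogen from ring position. Also open, on these data alone, is whether plain phenyl, or 4-methoxyphenyl with its oxygen-linked methyl, stays near the halogen-bearing compounds or moves towards compound 1.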